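Pyridin-2-yl replacing thiophen-3-yl on a shared core

The source may report more compounds than this note shows. Statements on the series, on what has been measured and on what is new or still open speak of the compounds shown alone.

Compound 1 `Oc1cccc(-c2cc(-c3ccc(Cl)cc3)nc(-c3cccs3)c2)c1` is measured in a functional assay on T47D cells (Homo sapiens) for cytotoxicity, read by CCK-8 assay and cell counting, with a stated time of 2 days (a higher number here means a weaker inhibitor, a lower number a stronger inhibitor), and gives 10500 nM. Compound 3 `Oc1cccc(-c2cc(-c3ccc(Cl)cc3)nc(-c3ccsc3)c2)c1` carries thiophen-3-yl where compound 1 carries thiophen-2-yl. In this assay compound 3 gives 11500 nM. The step between them, a 1.1-fold higher number from compound 1 to compound 3 (0.04 log units; within the scatter), is within the scatter, so compound 3 stands beside compound 1 with no real separation between the two numbers. Compound 2 `Oc1cccc(-c2cc(-c3cccc(Cl)c3)nc(-c3ccccn3)c2)c1`, which carries pyridin-2-yl together with a 3-chlorophenyl group, has "not determined" (no result reported) in this assay and therefore contributes no number.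

Compound 4 `Oc1cccc(-c2cc(-c3ccc(Cl)cc3)nc(-c3ccccn3)c2)c1` differs from compound 3 by the change (pyridin-2-yl in place of thiophen-3-yl on an aromatic carbon). Among the measured compounds shown here, the only measured step on the same position, a 1.1-fold higher number from compound 1 to compound 3 (0.04 log units; within the scatter), exchanges one thiophene for another and does not move the number beyond the scatter. For the measured compounds named here, no measured step replaces a five-membered ring by pyridin-2-yl, and compound 2, the one compound carrying that group, has no result. The expectation therefore rests on the flat step seen so far, and the estimated step of a 1.0-fold lower number from compound 3 to compound 4 (0.02 log units; within the scatter) is taken as none beyond the scatter. Compound 4 is accordingly expected to give 11000 nM in this assay, with a range from 4000 nM to 30000 nM.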

Compound 4, half-maximal inhibitory concentration: 13900 nM
Estimate against measurement, compound 4: 1.3-fold (0.10 log units) below; the measured number falls inside the stated range.
By their numbers in this assay, from the lowest: compounds 1, 3 and 4 (each within the scatter of the next).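

In this assay, the earlier step exchanged only one thiophene for another, whereas this one replaces a five-membered aromatic ring with a six-membered aromatic ring and a sulfur-containing ring with a nitrogen-containing one on the aromatic carbon next to the ring nitrogen, and the result is a 1.2-fold higher number from compound 3 to compound 4 (0.08 log units; within the scatter). The comparison with the other thiophene gives the same reading, a 1.3-fold higher number from compound 1 to compound 4 (0.12 log units; within the scatter), so with the 3-hydroxyphenyl and 4-chlorophenyl groups held constant, compounds 1, 3 and 4 cannot be separated by their numbers. No measurement available here bears on why the exchange of these rings leaves the numbers within the scatter of one another.

Going by these compounds, all three groups compared at this position are aromatic rings with one hetero atom, so it remains open whether the same reading would hold for a simple phenyl ring, a saturated piperidine ring, a primary amine or a carboxylic acid. On these data alone, it is also open whether the 3-hydroxyphenyl or 4-chlorophenyl group could be exchanged, for example for a methoxyphenyl or an unsubstituted phenyl group, with as little separation as seen for these three rings.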